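The compounds below may be only part of what the source reports. "The series", "measured", "known", "first", "only" and "open" are said of these compounds alone.

Measured compounds and their values:

compound 1 `Nc1ccccc1NC(=O)c1ccc(CSc2ccc(Br)cc2)cc1` — 38.2%
compound 2 `Nc1ccccc1NC(=O)/C=C/c1ccc(CSc2ccc(Cl)cc2)cc1` — 17.3%
compound 3 `Nc1ccccc1NC(=O)c1ccc(CSc2ccc(C(F)(F)F)cn2)cc1` — 16.5%

Of the compounds shown here, three have been tested in a functional assay on HeLa cells (Homo sapiens) for inhibition, read by CCK-8 assay, with a stated time of 72 h, tested at 8 uM; a lower number here means less inhibition of growth, a higher number more inhibition of growth at the concentration tested. Compound 1 gives 38.2%, the highest of the three numbers. Compound 2 stands second with 17.3%, and compound 3 gives 16.5%, a number within the usual scatter of that of compound 2, so the two cannot be ordered. Compound 1 lies beyond the scatter above compound 2.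

Compound 4 `Nc1ccccc1NC(=O)/C=C/c1ccc(CSc2ccc(C(F)(F)F)cn2)cc1` has not yet been measured in this assay. It differs from compound 2 in one place: 5-(trifluoromethyl)pyridin-2-yl in place of 4-chlorophenyl on a sulfur. Going by the values given here, no step of this kind between two measured compounds is available, so the size of the change cannot be read from the data. The nearest guide is that compound 3, which carries the entering group on a different core, gives 16.5%, a number close to that of compound 2.

Compound 4 is therefore expected to show a step of a number 2.3 percentage points lower from compound 2 to compound 4 (within the scatter), not beyond the scatter. The estimate for compound 4 in this assay is 15%, with a range from 4% to 28%.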

Compound 4, percent growth inhibition at one concentration: 6.82%
For compound 4 the middle estimate is 8.2 percentage points above the measured one, and the stated range covers the measured number.
By their numbers in this assay, from the lowest: compounds 4, 3 and 2 (each within the scatter of the next, the first and the last beyond it); then compound 1.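

In this assay, going by these compounds alone, the exchange of 4-chlorophenyl for 5-(trifluoromethyl)pyridin-2-yl on a sulfur gives a number 10.5 percentage points lower from compound 2 to compound 4 (beyond the scatter) and is the first step at this place that can be read on a single core. It shows that, on the core of compound 2, the number responds to the group carried by this sulfur, although the step is modest. No measured evidence bears on the reason for this step.

The compounds shown leave open whether the step follows the ring nitrogen or the trifluoromethyl group, a question that 4-(trifluoromethyl)phenyl or 5-chloropyridin-2-yl on the same sulfur could separate. They also leave open how this place would respond to a non-aromatic group such as cyclohexyl or to an aryl group bearing a carboxylic acid.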